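Trimming a methoxy group on the carbonyl-side ring

A few compounds are considered here, and "the series" means these few. Any claim that something is new, unique, unknown or untested is made for them only; others in the source may bear on it.

Measured compounds:
compound 1 `COc1cc(C(=O)/C=C/c2cc(-c3cc(OC)c(OC)c(OC)c3)n3nc(-c4ccccc4)cc3n2)cc(OC)c1OC` gives 34900 nM
compound 2 `COc1ccc(-c2cc(/C=C/C(=O)c3cc(OC)c(OC)c(OC)c3)nc3cc(-c4ccccc4)nn23)cc1OC` gives 8300 nM

In a functional assay on DU-145 cells (Homo sapiens) for antiproliferative activity, read by MTT assay, with a stated time of 24 h (a lower number here means a stronger inhibitor, a higher number a weaker inhibitor), compound 1 holds the highest of the two numbers; the step of a 4.2-fold lower number from compound 1 to compound 2 (0.62 log units; beyond the scatter) lies beyond the scatter. Compound 3 `COc1ccc(C(=O)/C=C/c2cc(-c3cc(OC)c(OC)c(OC)c3)n3nc(-c4ccccc4)cc3n2)cc1OC` is the new compound. It differs from compound 1 as follows: hydrogen in place of methoxy on an aromatic carbon. Among the measured compounds shown here, the only measured step that resembles this change is the one from compound 1 to compound 2, where the same kind of removal, on the other aromatic ring, gave a modest lowering of the number. For the measured compounds named here, that step is the sole guide here, and it is taken to suggest a lowering of similar or somewhat smaller size. Compound 3 is therefore expected to reach 12000 nM, within a range of 4500 nM to 35000 nM, so that the expected step is a 2.9-fold lower number from compound 1 to compound 3 (0.46 log units; beyond the scatter).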

Compound 3, half-maximal inhibitory concentration: 29900 nM
Compound 3: middle estimate off by 2.5-fold (0.40 log units), on the low side; the range from low to high includes it.
By their numbers in this assay, from the lowest: compound 2; then compounds 3 and 1 (each within the scatter of the next).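

In this assay, taking away one methoxy group on the carbonyl-side ring, so that 3,4,5-trimethoxyphenyl becomes 3,4-dimethoxyphenyl, gives a 1.2-fold lower number from compound 1 to compound 3 (0.07 log units; within the scatter), so no change can be read at this position. The same exchange of methoxy for hydrogen therefore does not read alike on the two aromatic rings: on the other ring it gave a 4.2-fold lower number from compound 1 to compound 2 (0.62 log units; beyond the scatter), a step beyond the scatter, while the step at this position stays within it. No measurement shown here accounts for this contrast.

The compounds shown leave open whether a hydroxyl group or an amine in this place would give a number different from methoxy or hydrogen. They also leave open what happens when a methoxy group is removed from both aromatic rings in one compound.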